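This account rests on a few compounds, and the source may have more. Where it says the series, first, only, none or still open, it means among the compounds named here.

Measured in a functional assay on the whole organism (Tail, strain ICR) with Mus musculus as the target, in the tail flick test, with a stated time of 150 min, at a dose of 25 umol/kg by the oral route; a lower number here means a weaker effect, a higher number a stronger effect of the compound at the dose given:
compound 1 `C[C@H](NC(=O)CN(c1nc(Cl)nc2[nH]cnc12)C1CC1)C(=O)OCc1ccccc1` gives 23%
compound 2 `O=C(CN(c1nc(Cl)nc2[nH]cnc12)C1CC1)N[C@@H](CC(=O)OCc1ccccc1)C(=O)OCc1ccccc1` gives 6.68%
compound 3 `O=C(CN(c1ncnc2c1ncn2C1CCCCO1)C1CC1)N[C@@H](CC(=O)OCc1ccccc1)C(=O)OCc1ccccc1` gives 0.06%

Compound 1 and compound 2 share a core, and the change between them is hydrogen in place of benzyloxycarbonyl on a saturated chain carbon, two bonds along the chain from an amide-type nitrogen and a carbonyl carbon. In this assay that change made a number 16.3 percentage points higher from compound 2 to compound 1 (beyond the scatter). Compound 3 carries a different core; how the core of compound 3 differs from that of compound 2 is not broken down here, and the values of compound 2 and compound 3 lie within the scatter of each other. Compound 4 `C[C@H](NC(=O)CN(c1ncnc2c1ncn2C1CCCCO1)C1CC1)C(=O)OCc1ccccc1` stands to compound 3 as compound 1 stands to compound 2: the change is hydrogen in place of benzyloxycarbonyl on a saturated chain carbon, two bonds along the chain from an amide-type nitrogen and a carbonyl carbon, the same kind of change at the same place. The step from compound 3 to compound 4 is expected to be a number 12.9 percentage points higher from compound 3 to compound 4 (beyond the scatter), resting on the earlier step of a number 16.3 percentage points higher from compound 2 to compound 1 (beyond the scatter) made on the other core. Compound 4 is therefore estimated at 13%, expected between 0% and 30%.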

Compound 4, a percentage reported as activity, at one dose (the size of the read-out at that dose, not a potency): 6.01%
Beside the measured number, compound 4's estimate is 7 percentage points above it; measured number inside the range.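

In this assay, putting hydrogen in place of benzyloxycarbonyl gave a number 6 percentage points higher from compound 3 to compound 4 (within the scatter), so on this core the change has no effect that can be told from the scatter. Set beside the earlier step, the two cores cannot be told apart in their response to this change: the same change on two cores in this assay, a number 16.3 percentage points higher (beyond the scatter) from compound 2 to compound 1 and a number 6 percentage points higher (within the scatter) from compound 3 to compound 4, 10.4 percentage points apart, within the scatter of two such steps This shows no measurable difference in how the change carries over, but with one pair per core it does not show that the step is truly the same size on both.

The compounds shown leave open how a free carboxylic acid in place of the benzyl ester, or a longer chain in place of the methyl, would read in this assay. With a single dose, they also leave open whether the change would give a stronger or weaker effect at any other dose.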